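The source may hold more compounds than are shown below. What is called first, only, known or untested is meant among the compounds shown, and "the series" means these compounds.

Three compounds share one core and were tested in an assay on CHO cells for displacement of a labelled ligand from adenosine receptor A1 (Homo sapiens); on this read-out lower numbers stand for stronger inhibition and higher numbers for weaker inhibition. Compound 1 `CC(C)Cn1c(=O)c2nc(-c3cnn(Cc4cccc(F)c4)c3)[nH]c2n(CC(C)C)c1=O` gives 830 nM, compound 2 `CCn1c(=O)c2nc(-c3cnn(Cc4cccc(F)c4)c3)[nH]c2n(CC)c1=O` gives 380 nM, and compound 3 `CCCn1c(=O)c2nc(-c3cnn(Cc4cccc(Cl)c4)c3)[nH]c2n(CCC)c1=O` gives 31 nM. Compound 2 thus holds the second highest of the three numbers: compound 1 gives a higher number, beyond the usual scatter, while compound 3 gives a much lower one, also beyond it. Compound 4 `CCn1c(=O)c2nc(-c3cnn(Cc4ccccc4)c3)[nH]c2n(CC)c1=O` has not yet been measured. It differs from compound 2 in one place: hydrogen in place of fluoro on an aromatic carbon. Only the fluoro is removed; everything else stays. For the measured compounds named here, no measured pair shows this change, so the step in this assay is expected to be small, probably a slightly higher number, close to the scatter. Compound 4 is therefore expected to give about 550 nM, with a range from 250 nM to 1200 nM. The expected step is a 1.4-fold higher number from compound 2 to compound 4 (0.16 log units; within the scatter).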

Compound 4, inhibition constant: 580 nM
Compound 4: middle estimate off by 1.1-fold (0.02 log units), on the low side; the range from low to high includes it.
By their numbers in this assay, from the lowest: compound 3; then compounds 2, 4 and 1 (each within the scatter of the next, the first and the last beyond it).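

Removing the fluoro from the 3-fluorobenzyl group gives in this assay a 1.5-fold higher number from compound 2 to compound 4 (0.18 log units; within the scatter) and so, on this read-out, fluoro and hydrogen at this place on the aromatic ring cannot be told apart. For the compounds shown here, this is the first measured pair that differs in one place only, and the earlier compounds offered no such direct comparison. No further data here bear on this result. 

From the compounds shown here alone, whether a chloro, a methoxy or an amine at this place would shift the number beyond the scatter stays open. Also open, going by these compounds, is whether removing the fluoro gives the same small step when the chains on the shared core are propyl or isobutyl rather than ethyl.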